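Removing Methoxymethyl from Compound 3

The source may hold more compounds than are shown below. What is called first, only, known or untested is meant among the compounds shown, and "the series" means these compounds.

In a functional assay on MCF7 cells (Homo sapiens) for antiproliferative activity, read by MTT assay (a lower number here means a stronger inhibitor, a higher number a weaker inhibitor), compound 3 (`CCCCC/C=C\C/C=C\CCCCCCCc1cc(=O)c2c(O)c(C)c(OCOC)cc2o1`) gives > 67200 nM, which is a limit of the assay and not a number. Compound 3 therefore stands at the limit of > 67200 nM in this assay, at which 2 of the 3 values shown sit. Compound 1 (`CCCCCCCCCCCCCCCc1cc(=O)c2c(O)c(C)c(OCOC)cc2o1`) gives > 67200 nM, also a limit. Among the measured compounds shown here, the one measured step is a step that the two limits leave unreadable from compound 1 to compound 3, so it offers no size to carry over.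

Compound 4 (`CCCCC/C=C\C/C=C\CCCCCCCc1cc(=O)c2c(O)c(C)c(O)cc2o1`) is made from compound 3 by a single change: hydrogen in place of methoxymethyl on an oxygen on an aromatic ring. In words, hydrogen takes the place of methoxymethyl on an oxygen on an aromatic ring, so methoxymethoxy becomes hydroxy. For the measured compounds named here, no measured step isolates this change. The nearest guide is compound 2 (`CC/C=C\C/C=C\C/C=C\CCCCCCCc1cc(=O)c2c(O)c(C)c(O)cc2o1`), which carries hydroxy in that place on a different unsaturated chain and gives a measured 17500 nM.

On the strength of compound 2 at 17500 nM, a change toward stronger inhibition is expected, and the estimated step is an at least 3.3-fold lower number from compound 3 to compound 4 (0.52 log units; beyond the scatter). Compound 4 is expected at an estimated 20000 nM, with a range of 9000 nM to 45000 nM.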

Compound 4, half-maximal inhibitory concentration: > 84100 nM
Compound 4: no number, only a limit; the forecaster's own chance of this, stated with the estimate: 15%; at least 4.2-fold (0.62 log units) between middle value and limit.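

In this assay compound 4 gives > 84100 nM, a limit of the assay and not a number. Hydroxy at this position therefore does not by itself give a measurable value, and with hydroxy held constant, the chain change of butyl in place of but-1-en-1-yl on a saturated chain carbon bound to a double-bonded chain carbon gives an at least 4.8-fold higher number from compound 2 to compound 4 (0.68 log units; beyond the scatter). The step from methoxymethoxy to hydroxy between compound 3 and compound 4 cannot be read, since both ends are limits: the limit of > 84100 nM in this assay, at which 1 of the 4 values shown sits.

The compounds shown leave open what methoxymethoxy in place of hydroxy would do on the chain of compound 2, where a number exists to compare against. They also leave open whether a carboxylic acid or an amine at the end of the chain would bring compound 4 into measurable range.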